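Swapping chloro for nitro on the arylthio ring

This account rests on a few compounds, and the source may have more. Where it says the series, first, only, none or still open, it means among the compounds named here.

Two close relatives of one purine nucleoside have been tested in an assay on isolated protein for binding affinity to Equilibrative nucleoside transporter 1 (Homo sapiens); a lower number here means a stronger inhibitor, a higher number a weaker inhibitor. Compound 1 `OC[C@H]1O[C@@H](n2cnc3c(CSc4ccccc4Br)ncnc32)[C@H](O)[C@@H]1O` gives 2400 nM. Among the compounds with values here, compound 2 `OC[C@H]1O[C@@H](n2cnc3c(CSc4cccc(Cl)c4)ncnc32)[C@H](O)[C@@H]1O` gives 282 nM, the lowest of the two numbers; the only measured step, an 8.5-fold lower number from compound 1 to compound 2 (0.93 log units; beyond the scatter), separates them. Compound 3 `O=[N+]([O-])c1cccc(SCc2ncnc3c2ncn3[C@@H]2O[C@H](CO)[C@@H](O)[C@H]2O)c1` has not yet been measured. It differs from compound 2 in one place: nitro in place of chloro on an aromatic carbon. Within the data shown here, no measured step exchanges one substituent for another at a fixed position on this ring, so the only guidance is the step of an 8.5-fold lower number from compound 1 to compound 2 (0.93 log units; beyond the scatter), which shows that changing what sits on this ring moves the number by a modest amount. A change of similar or smaller size is therefore expected for compound 3, with the direction uncertain and leaning toward a slightly lower number, giving an estimated step of a 1.4-fold lower number from compound 2 to compound 3 (0.15 log units; within the scatter). Compound 3 is expected to give about 200 nM, within a range of 50 nM to 800 nM.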

Compound 3, half-maximal inhibitory concentration: 4.79 nM
Compound 3: middle estimate off by 42-fold (1.62 log units), on the high side; measured number below the stated range.
By their numbers in this assay, from the lowest: compound 3; then compound 2; then compound 1.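

In this assay, within the data shown here, swapping chloro for nitro with the ring position held fixed gives a 59-fold lower number from compound 2 to compound 3 (1.77 log units; beyond the scatter) and is the first step here to isolate the group itself. It shows that the number at this position depends strongly on which group sits there, and that this one exchange moves it much further than the earlier step did. That earlier step changed both the group and its place on the ring, and the wider comparison, a 500-fold lower number from compound 1 to compound 3 (2.70 log units; beyond the scatter), likewise changes both, so neither separates the two effects.

Going by these compounds, whether a nitrile, a carboxylic acid or an amine at this same position would match nitro remains open, as does how nitro would behave elsewhere on the ring. Nothing available explains why nitro gives so much lower a number than chloro.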